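Working notes: bromo for hydrogen on two different cores

The source may hold more compounds than are shown below. What is called first, only, known or untested is meant among the compounds shown, and "the series" means these compounds.

Measured so far in a functional assay on PC-3 cells (Homo sapiens) for antiproliferative activity, read by MTT assay, with a stated time of 72 h; a higher number here means a weaker inhibitor, a lower number a stronger inhibitor:
compound 1 `O=C(COc1ccc(C(=O)/C=C/c2cccc(Br)c2)cc1)N[C@H]1CCOC1=O` gives 7890 nM
compound 3 `O=C(COc1ccc(C(=O)/C=C/c2ccccc2)cc1)N[C@H]1CCOC1=O` gives 56800 nM
compound 2 `O=C(CNc1ccccc1)N[C@H]1CCOC1=O` gives only a limit, > 64000 nM, not a number

Compound 3 and compound 1 differ by bromo in place of hydrogen on an aromatic carbon; in this assay the step is a 7.2-fold lower number from compound 3 to compound 1 (0.86 log units; beyond the scatter). For compound 2 the assay reports only a limit (the limit of > 64000 nM in this assay, at which 1 of the 3 values shown sits), so no number is known for it. How the core of compound 2 differs from the core of compound 3 is not broken down here.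

Compound 4 `O=C(CNc1ccc(Br)cc1)N[C@H]1CCOC1=O` is not yet measured. It differs from compound 2 by bromo in place of hydrogen on an aromatic carbon. The place is not the same as in compound 1: there the bromo sits meta to a large group, in compound 4 para to a large group, so this is the same kind of change, not the same change.

From compound 2 to compound 4 the expected step is an at least 2.1-fold lower number from compound 2 to compound 4 (0.32 log units; beyond the scatter), set beside a 7.2-fold lower number from compound 3 to compound 1 (0.86 log units; beyond the scatter); this rests on that one measured step and on compound 2 having only a limit, which leaves the starting point open. Compound 4 is estimated at 30000 nM, expected between 10000 nM and 70000 nM.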

Compound 4, half-maximal inhibitory concentration: > 64000 nM
Compound 4 ended at the assay's limit; the forecaster's own chance of this, stated with the estimate: 45%; middle value at least 2.1-fold (0.32 log units) from the limit.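

Compound 2 and compound 4 both give only a limit in this assay, not a number, so no new step can be read for bromo in place of hydrogen on this core: the limit of > 64000 nM in this assay, at which 2 of the 4 values shown sit.

Left open is whether a 7.2-fold lower number from compound 3 to compound 1 (0.86 log units; beyond the scatter) has any counterpart on the core of compound 2.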